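From 2-chlorophenyl to 4-chlorophenyl in compound 3

This account rests on a few compounds, and the source may have more. Where it says the series, first, only, none or still open, it means among the compounds named here.

In a functional assay on DU-145 cells (Homo sapiens) for antiproliferative activity, read by MTT assay, with a stated time of 48 h (on this read-out lower numbers stand for stronger inhibition and higher numbers for weaker inhibition), compound 1 `COc1ccc(-n2cc(COC(=O)/C(C)=C/CC/C(C)=C/CC/C(C)=C/CC[C@@H]3[C@@]4(C)CCC(=O)C(C)(C)[C@H]4CC[C@@]3(C)O)nn2)cc1` gives 135000 nM as its measured value. Compound 2 `C/C(=C\CC/C(C)=C/CC[C@@H]1[C@@]2(C)CCC(=O)C(C)(C)[C@H]2CC[C@@]1(C)O)CC/C=C(\C)C(=O)OCc1cn(-c2ccccc2Cl)nn1` shows > 150000 nM which is a limit of the assay and not a number. Going by the values given here, the single measured step is an at least 1.1-fold higher number from compound 1 to compound 2 (0.04 log units; that floor lies within the scatter) and it is the only guide to changes on this aromatic nitrogen. Compound 3 `C/C(=C\CC/C(C)=C/CC[C@@H]1[C@@]2(C)CCC(=O)C(C)(C)[C@H]2CC[C@@]1(C)O)CC/C=C(\C)C(=O)OCc1cn(-c2ccc(Cl)cc2)nn1` differs from compound 2 by 4-chlorophenyl in place of 2-chlorophenyl on an aromatic nitrogen with 4-chlorophenyl in place of 2-chlorophenyl on an aromatic nitrogen. From that one step, the estimated change in this assay is a number no higher from compound 2 to compound 3 (the limit leaves the size open) and nothing beyond the scatter is expected. The expected value for compound 3 is 150000 nM within a range of 90000 nM to 250000 nM on this read-out.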

Compound 3, half-maximal inhibitory concentration: > 150000 nM
Compound 3: a limit, no number (the forecaster's own chance of this, stated with the estimate: 50%); the middle value lies on the limit itself.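

In this assay compound 3 gives > 150000 nM, which is a limit of the assay and not a number. The step between the 2-chlorophenyl and 4-chlorophenyl compounds therefore cannot be read, so nothing shows whether moving the chlorine matters: the limit of > 150000 nM in this assay, at which 2 of the 3 values shown sit. Chloro in place of methoxy gives an at least 1.1-fold higher number from compound 1 to compound 3 (0.04 log units; that floor lies within the scatter), so neither chlorophenyl compound is shown to differ from the 4-methoxyphenyl compound beyond the scatter.

Still open, from the compounds shown here alone, is whether a phenyl ring carrying an amine or a carboxylic acid would give a measurable number in this assay.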